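The source may hold more compounds than are shown below. What is called first, only, known or untested is meant among the compounds shown, and "the series" means these compounds.

Compound 1 `CS(=O)(=O)Nc1ccc(Cl)c2c1CCCC2c1c[nH]cn1`: < 10000 nM
Compound 2 `CCS(=O)(=O)Nc1cc(C2CCCCC2)cc2c1CCCC2c1c[nH]cn1`: 891 nM
Compound 3 `CCS(=O)(=O)Nc1cccc(C2CCNC2)c1`: < 10000 nM

In an assay on isolated protein (Cricetulus griseus) for binding affinity to Alpha-1B adrenergic receptor (Mesocricetus auratus), read by radioligand binding (on this read-out lower numbers stand for stronger inhibition and higher numbers for weaker inhibition), compound 3 gives only a limit of the assay, < 10000 nM, and no number. Compound 1 likewise gives a limit, < 10000 nM. Compound 2 gives a number, 891 nM. For the measured compounds named here, two of the three values thus sit at the limit of < 10000 nM in this assay, at which 2 of the 3 values shown sit, and no pair of measured compounds differs in a single place, so no measured step is available to calibrate a change.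

Compound 4 `CCS(=O)(=O)Nc1cccc(NC2=NCCN2)c1` is the next compound to be run in this assay. It differs from compound 3 as follows: a group of 6 heavy atoms (3 carbon, 3 nitrogen; one five-membered non-aromatic ring with 2 hetero atoms) in place of a group of 5 heavy atoms (4 carbon, 1 nitrogen; one five-membered non-aromatic ring with 1 hetero atom), on an aromatic carbon. Going by the values given here, with compound 3 known only as a limit and no measured step behind this kind of change, the direction of the step cannot be read from the present data; the working expectation for the step is a step that the limit leaves unreadable from compound 3 to compound 4, which is a modest shift, possibly none beyond the scatter. Compound 4 is estimated at 3000 nM, within a range from 300 nM to 10000 nM, with a fair chance that this assay again reports only a limit.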

Compound 4, inhibition constant: < 10000 nM
Compound 4: no number, only a limit; the forecaster's own chance of this, stated with the estimate: 40%; the middle value does not contradict the limit.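

Compound 3 and compound 4 both give only a limit in this assay, so no step between them can be read: the limit of < 10000 nM in this assay, at which 3 of the 4 values shown sit.

Going by these compounds, whether putting the new five-membered ring with 2 hetero atoms in place of pyrrolidin-3-yl shifts binding affinity at all stays open.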